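A few compounds are considered here, and "the series" means these few. Any claim that something is new, unique, unknown or untested is made for them only; others in the source may bear on it.

In an ADME assay on L02 cells (Homo sapiens) for cytotoxicity, read by MTT assay, with a stated time of 24 h (on this read-out higher numbers stand for weaker inhibition and lower numbers for stronger inhibition), compound 1 `CN1C/C(=C\c2ccc(F)cc2)C(=O)/C(=C/c2cccc([N+](=O)[O-])c2)C1` gives 17600 nM. Compound 2 `CN1C/C(=C\c2ccc(Cl)cc2)C(=O)/C(=C/c2cccc([N+](=O)[O-])c2)C1` gives > 20000 nM, which is a limit of the assay and not a number. Compound 2 therefore has no exact position in the series, and (the limit of > 20000 nM in this assay, at which 1 of the 2 values shown sits).

The next change leads to compound 3 `CN1C/C(=C\c2ccc(Br)cc2)C(=O)/C(=C/c2cccc([N+](=O)[O-])c2)C1`: bromo in place of chloro on an aromatic carbon, para to a large group. Among the compounds with values here, one measured step bears on it, a halogen exchange on the same aromatic carbon, chloro in place of fluoro: an at least 1.1-fold higher number from compound 1 to compound 2 (0.05 log units; that floor lies within the scatter). As far as these compounds go, that step gives no change beyond the scatter, though its true size remains open. No step beyond the scatter is therefore expected in this assay. The estimated change is a number no higher from compound 2 to compound 3 (the limit leaves the size open). The estimate for compound 3 is 20000 nM, with an expected range of 10000 nM to 40000 nM.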

Compound 3, half-maximal inhibitory concentration: 9850 nM
Compound 3: middle estimate off by 2.0-fold (0.31 log units), on the high side, outside the stated range (below it).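

In this assay, compound 3 puts an exact value on the bromo side of this halogen exchange, para to a large group, and the change from the chloro compound reads an at least 2.0-fold lower number from compound 2 to compound 3 (0.30 log units; that floor lies within the scatter). The comparison with the fluoro compound reads a 1.8-fold lower number from compound 1 to compound 3 (0.25 log units; within the scatter), so the two exact values at this position do not separate and no order between fluoro and bromo can be drawn. Compound 2 carries a limit of the assay and not a number, so the true size of the chloro to bromo step stays open: the limit of > 20000 nM in this assay, at which 1 of the 3 values shown sits.

Open, as far as these compounds go, is how an amine or a carboxylic acid in place of the halogen would read in this assay. Also open, from the compounds shown here alone, is whether the values at this position hold when the nitro group elsewhere on the shared core gives way to a nitrile.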